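Swapping a pendant chain for a fluorinated ring

The compounds below may be only part of what the source reports. "The series", "measured", "known", "first", "only" and "open" are said of these compounds alone.

Measured compounds:
compound 1, `Fc1ccc(-c2ccc3c(NCCCNCc4ccco4)ccnc3c2)cc1`, 9.47
compound 2, `COc1ccc(F)cc1CNCCCNc1ccnc2cc(CCc3ccccc3)ccc12`, 9.47
compound 3, `FC(F)(F)c1ccc(-c2ccc3c(NCCCNCc4ccco4)ccnc3c2)cc1`, 9.47

In a physicochemical assay for acid dissociation, compound 2 stands level with the other two: its nearest neighbour is compound 1 and its furthest is compound 3, and both sit at the same value at the digits given, within the scatter. Going by the values given here, the one measured step, no change at the digits printed from compound 1 to compound 3 (within the scatter), shows that a change of the group hanging from the shared core left the read-out untouched.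

Compound 4, `COc1ccc(F)cc1CNCCCNc1ccnc2cc(-c3ccc(F)cc3)ccc12`, is not yet measured. Relative to compound 2 the change is 4-fluorophenyl in place of phenethyl on an aromatic carbon. Among the compounds with values here, the step between compound 1 and compound 3 is the only comparison that bears on this kind of change; it altered the pendant group on the core and moved nothing. On that basis the expected step of no change at the digits printed from compound 2 to compound 4 (within the scatter) is none beyond the scatter. Compound 4 is therefore estimated at 9.47, with a range from 9.15 to 9.8.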

Compound 4, acid dissociation constant: 9.47
Beside the measured number, compound 4's estimate shows no gap at the digits printed; the range from low to high includes it.
By their numbers in this assay, from the lowest: compounds 1, 2, 3 and 4 (each within the scatter of the next).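

In this assay, the swap of phenethyl for 4-fluorophenyl on the aromatic carbon of the shared core gives no change at the digits printed from compound 2 to compound 4 (within the scatter). This goes further than the earlier comparison, which only exchanged one substituent on an aromatic ring: here the whole group on the core is replaced, and the read-out still does not separate the two. Compound 4 also extends the picture to a second place in the molecule, since 5-fluoro-2-methoxyphenyl in place of furan-2-yl on a saturated chain carbon bound to an amine nitrogen gives no change at the digits printed from compound 1 to compound 4 (within the scatter), and no other information bears on why these values coincide.

Going by these compounds, all the groups compared at these two places are carbon-linked rings or chains without an ionisable atom of their own, so it remains open whether an amine or a carboxylic acid on the same aromatic carbon would leave this assay equally unmoved. The chain joining the two nitrogens is also the same throughout, which leaves open what a longer chain or a shorter one would do to the value.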